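Chloro to diethylamino: notes on the next step

The compounds below may be only part of what the source reports. "The series", "measured", "known", "first", "only" and "open" are said of these compounds alone.

In a functional assay on HepG2 cells (Homo sapiens) for antiproliferative activity, read by MTT assay, with a stated time of 48 h (a higher number here means a weaker inhibitor, a lower number a stronger inhibitor), compound 3 (`COc1ccc(/C=C/c2cc(OC)cc(OC)c2/C=C/C(=O)c2ccc(Cl)cc2)cc1`) gives 13.6 ug/mL. This lies within the scatter of compound 1 (`CCCC(C)Oc1ccc(C(=O)/C=C/c2c(/C=C/c3ccc(OC)cc3)cc(OC)cc2OC)cc1`) at 11.1 ug/mL, whereas compound 2 (`COc1ccc(/C=C/c2cc(OC)cc(OC)c2/C=C/C(=O)c2ccc(C)cc2)cc1`) gives 4.8 ug/mL. The next change leads to compound 4 (`CCN(CC)c1ccc(C(=O)/C=C/c2c(/C=C/c3ccc(OC)cc3)cc(OC)cc2OC)cc1`), with diethylamino in place of chloro on an aromatic carbon, para to a large group: diethylamino in place of chloro on an aromatic carbon.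

Among the measured compounds shown here, three measured steps bear on this place. Chloro in place of methyl gave a 2.8-fold higher number from compound 2 to compound 3 (0.45 log units; beyond the scatter), methyl in place of 1-methylbutoxy gave a 2.3-fold lower number from compound 1 to compound 2 (0.36 log units; beyond the scatter), and chloro in place of 1-methylbutoxy gave a 1.2-fold higher number from compound 1 to compound 3 (0.09 log units; within the scatter). These steps are modest at most, although the groups differ widely. For the measured compounds named here, no diethylamino compound has been measured, so the direction is weakly supported. Compound 4 is expected to fall inside the span already seen, which leaves more room below the value of compound 3 than above it. Going by the values given here, the estimated change is a 1.5-fold lower number from compound 3 to compound 4 (0.18 log units; within the scatter), with no large step expected. For compound 4 the estimate is 9 ug/mL, with an expected range of 4 ug/mL to 20 ug/mL.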

Compound 4, half-maximal inhibitory concentration: 6.3 ug/mL
Estimate against measurement, compound 4: 1.4-fold (0.15 log units) above; low and high end bracket the measured number.
By their numbers in this assay, from the lowest: compounds 2, 4, 1 and 3 (each within the scatter of the next, the first and the last beyond it).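

In this assay the place para to a large group now also carries a nitrogen-linked substituent, and diethylamino in place of chloro gives a 2.2-fold lower number from compound 3 to compound 4 (0.33 log units; beyond the scatter) as a modest gain. Against the other two groups, diethylamino gives a 1.3-fold higher number from compound 2 to compound 4 (0.12 log units; within the scatter) and a 1.8-fold lower number from compound 1 to compound 4 (0.25 log units; within the scatter) and so separates from neither methyl nor 1-methylbutoxy, which leaves chloro apart from methyl and diethylamino but not from 1-methylbutoxy, with compound 1 going against any simple split of the four groups. No measurement accompanies these values that could tie the differences to any property of the groups.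

Open, going by these compounds, is whether a smaller amine such as dimethylamino or a ring amine such as morpholine behaves like diethylamino here. A carboxylic acid at this place also remains untested in the compounds shown.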